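The source may report more compounds than this note shows. Statements on the series, on what has been measured and on what is new or still open speak of the compounds shown alone.

In a functional assay on cells (Leukemia cell, Homo sapiens) for cytotoxicity, read by sulforhodamine B assay, with a stated time of 48 h (a higher number here means a weaker inhibitor of growth, a lower number a stronger inhibitor of growth), the three measured compounds gave these numbers:

Compound 1 `O=C1N=C(N2N=C(c3ccccc3)CC2c2ccccc2O)S/C1=C1/C(=O)Nc2ccc(Br)cc21`: 1050 nM
Compound 2 `COc1ccc(C2CC(c3ccccc3)=NN2C2=NC(=O)/C(=C3\C(=O)Nc4ccc(Br)cc43)S2)cc1`: 4230 nM
Compound 3 `CN(C)c1ccc(C2CC(c3ccccc3)=NN2C2=NC(=O)/C(=C3\C(=O)Nc4ccccc43)S2)cc1`: 45600 nM

Compound 3 stands highest of the three, beyond the scatter of both others, so it is the weakest growth inhibitor here. Compound 4 `CN(C)c1ccc(C2CC(c3ccccc3)=NN2C2=NC(=O)/C(=C3\C(=O)Nc4ccc(Br)cc43)S2)cc1` differs from it by bromo in place of hydrogen on an aromatic carbon. Going by the values given here, no measured pair differs by this change alone. Among the compounds with values here, the only measured step, a 4.0-fold higher number from compound 1 to compound 2 (0.61 log units; beyond the scatter), swaps the group on the saturated ring carbon and says nothing about bromo. Compounds 1 and 2 both carry bromo and show lower numbers than compound 3, yet they also carry a different aryl group, so they bear only loosely. A modest downward step is expected for compound 4, a 2.3-fold lower number from compound 3 to compound 4 (0.36 log units; beyond the scatter). Compound 4 is estimated at 20000 nM, within 6000 nM to 60000 nM.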

Compound 4, concentration for total growth inhibition: 1290 nM
For compound 4 the middle estimate is 16-fold (1.19 log units) above the measured one; measured number outside the range, below it.
By their numbers in this assay, from the lowest: compounds 1 and 4 (each within the scatter of the next); then compound 2; then compound 3.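

In this assay, bromo in place of hydrogen on this aromatic carbon gives a 35-fold lower number from compound 3 to compound 4 (1.55 log units; beyond the scatter), so a single added atom can change the result greatly. With bromo present, dimethylamino in place of methoxy gives a 3.3-fold lower number from compound 2 to compound 4 (0.52 log units; beyond the scatter), and 4-(dimethylamino)phenyl in place of 2-hydroxyphenyl gives a 1.2-fold higher number from compound 1 to compound 4 (0.09 log units; within the scatter). Nothing available explains the size of the bromo step.

Going by these compounds, it remains open whether chloro, fluoro or methoxy on this aromatic carbon would match bromo. On these data alone, it is also open whether bromo would give a similar step alongside the 2-hydroxyphenyl group of compound 1.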